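A few compounds are considered here, and "the series" means these few. Any claim that something is new, unique, unknown or untested is made for them only; others in the source may bear on it.

Compound 1 `Cc1cc(C)cc(Cn2c(=O)cc(NC3CC3)n(Cc3ccccc3)c2=O)c1` is the reference point of the series in an ADME assay on MT4 cells (Homo sapiens) for cytotoxicity, read by MTT assay, with a stated time of 4 days; a lower number here means that less compound is tolerated, a higher number that more compound is tolerated. In this assay compound 1 gives > 100000 nM, which is a limit of the assay and not a number. Compound 2 `Cc1cc(C)cc(Cn2c(=O)cc(N=[N+]=[N-])n(Cc3ccccn3)c2=O)c1` gives > 100000 nM, again a limit. Compound 3 `Cc1cc(C)cc(Cn2c(=O)cc(NCc3ccccc3)n(Cc3ccccc3)c2=O)c1` gives > 100000 nM, also a limit. Among the compounds with values here, the one measured step at the site of interest, benzyl in place of cyclopropyl on a ring nitrogen, reads as a step that the two limits leave unreadable from compound 1 to compound 3 and cannot be sized because of the limit of > 100000 nM in this assay, at which 3 of the 3 values shown sit.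

Compound 4 `Cc1cc(C)cc(Cn2c(=O)cc(N3CCCC3)n(Cc3ccccc3)c2=O)c1` differs from compound 1 by pyrrolidin-1-yl in place of cyclopropylamino on an aromatic carbon. Within the data shown here, no measured step gives a readable size for a change of this kind; all three values sit at the assay limit, and the cyclopropyl to benzyl exchange left that unchanged. Compound 4 is therefore expected in this assay at 150000 nM, with a range of 60000 nM to 400000 nM. The expected step that the limit leaves unreadable from compound 1 to compound 4 is taken as none beyond the scatter, with a result most likely reported again as a limit.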

Compound 4, half-maximal cytotoxic concentration: 31000 nM
For compound 4 the middle estimate is 4.8-fold (0.68 log units) above the measured one, outside the stated range (below it).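

In this assay, the position on the aromatic carbon opposite the ring nitrogen proves able to change tolerance: pyrrolidin-1-yl gives an at least 3.2-fold lower number from compound 1 to compound 4 (0.50 log units; beyond the scatter), and against benzylamino it gives an at least 3.2-fold lower number from compound 3 to compound 4 (0.50 log units; beyond the scatter). The two secondary amines remain unreadable against each other, so pyrrolidin-1-yl alone separates from the other groups at this position. Both steps give only a minimum size, because their starting values are limits: the limit of > 100000 nM in this assay, at which 3 of the 4 values shown sit.

The exchange from cyclopropylamino to pyrrolidin-1-yl changes both the ring and the hydrogen-bond donor count, from 1 to 0, and compound 4 alone cannot separate these two changes. A dimethylamino, piperidin-1-yl or morpholin-4-yl group at this position would show whether the lower number belongs to pyrrolidin-1-yl specifically or extends to other amines without the amine hydrogen.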